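Piperazine aryl variation in a benzamide series: compound 4

This account rests on a few compounds, and the source may have more. Where it says the series, first, only, none or still open, it means among the compounds named here.

Measured compounds:
compound 1 `Nc1ccccc1NC(=O)c1ccc(CSC(=S)N2CCN(c3ccc(Cl)cc3)CC2)cc1` — 17.2%
compound 2 `Nc1ccccc1NC(=O)c1ccc(CSC(=S)N2CCN(c3ccncc3)CC2)cc1` — 87.1%
compound 3 `Nc1ccccc1NC(=O)c1ccc(CSC(=S)N2CCN(c3ncccn3)CC2)cc1` — 64.8%

Of the compounds shown here, three sharing one core have been tested in a functional assay on MGC-803 cells (Homo sapiens) for antiproliferative activity, read by CCK-8 assay, with a stated time of 72 h, tested at 8 uM (a higher number here means a stronger effect of the compound at the concentration tested, a lower number a weaker effect), differing only in the group on an amine nitrogen in a ring. Compound 3 stands second highest of the three: its nearest neighbour is compound 2, with a number 22.3 percentage points lower from compound 2 to compound 3 (beyond the scatter), and its furthest is compound 1, with a number 47.6 percentage points higher from compound 1 to compound 3 (beyond the scatter). Both heteroaryl groups sit well above the 4-chlorophenyl of compound 1, as a number 69.9 percentage points higher from compound 1 to compound 2 (beyond the scatter) also shows.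

Compound 4 `N#Cc1ccc(N2CCN(C(=S)SCc3ccc(C(=O)Nc4ccccc4N)cc3)CC2)cc1` is the next member; it carries 4-cyanophenyl in place of pyrimidin-2-yl on an amine nitrogen in a ring. For the measured compounds named here, the change returns to a six-membered aromatic ring of carbon only, as in compound 1, but with a nitrile rather than a chlorine, for which no measured pair exists. The step bearing most on it is the reverse of compound 1 to compound 3, which was large. A downward step is therefore expected, tempered by the unmeasured effect of the nitrile: a number 29.8 percentage points lower from compound 3 to compound 4 (beyond the scatter). For compound 4 the estimate in this assay is 35%, within 10% to 70%.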

Compound 4, a percentage reported as inhibition, at one concentration (the size of the read-out at that concentration, not a potency): 37.6%
The estimate for compound 4 lay 2.6 percentage points below the measured number, within the range that was stated.
By their numbers in this assay, from the lowest: compound 1; then compound 4; then compound 3; then compound 2.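

In this assay, the carbon-only ring of compound 4 stays under both heteroaryl groups, with a number 27.2 percentage points lower from compound 3 to compound 4 (beyond the scatter) and a number 49.5 percentage points lower from compound 2 to compound 4 (beyond the scatter), so among these four compounds both carbon-only rings fall below both nitrogen-containing rings. The exchange of cyano for chloro gives a number 20.4 percentage points higher from compound 1 to compound 4 (beyond the scatter), the first sign that the group carried on the carbon ring also moves the number at this position, although not as far as the heteroaryl rings do. No measured evidence bears on the reason for these differences.

Open, going by these compounds, is where an unsubstituted phenyl group would fall, and whether a methoxy or an amine group in place of the nitrile would move the number further. Also open, on these data alone, is whether a pyrazine ring would stand with compound 2 or with compound 3.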